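The compounds below may be only part of what the source reports. "The series", "measured", "known", "first", "only" and "open" are said of these compounds alone.

Measured so far:
compound 1 `CCCC[S+]([O-])c1sc2nc(-c3nccs3)cc(-c3ccc(C(=O)OC)cc3)c2c1N`: 15.1 nM
compound 2 `CCCC[S+]([O-])c1sc2nc(-c3ncco3)cc(-c3ccccc3)c2c1N`: 1.4 nM

In an assay for inhibition of 15-hydroxyprostaglandin dehydrogenase [NAD(+)] (Homo sapiens), read by fluorescence, with a stated time of 15 min, in the presence of a further agent that is not named here (a lower number here means a stronger inhibitor, a higher number a weaker inhibitor), compound 1 gives 15.1 nM, the higher of the two numbers. Compound 2 gives 1.4 nM, a gap beyond the usual scatter, so compound 1 stands as the weaker of the two.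

Compound 3 `CCCC[S+]([O-])c1sc2nc(-c3nccs3)cc(-c3ccc(CNS(C)(=O)=O)cc3)c2c1N` differs from compound 1 in a single place: (methanesulfonamido)methyl in place of methoxycarbonyl on an aromatic carbon. Among the compounds with values here, no measured pair shows what this change does, so its effect cannot be read from the data. In this assay only a modest step is expected, in either direction, likely within the scatter.

Compound 3 is expected to give about 12 nM, within 4 nM to 40 nM, an expected step of a 1.3-fold lower number from compound 1 to compound 3 (0.10 log units; within the scatter).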

Compound 3, half-maximal inhibitory concentration: 4.6 nM
Beside the measured number, compound 3's estimate is 2.6-fold (0.42 log units) above it, and the stated range covers the measured number.
By their numbers in this assay, from the lowest: compound 2; then compound 3; then compound 1.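

On the six-membered aromatic ring of carbon only, at the carbon para to a large group, (methanesulfonamido)methyl in place of methoxycarbonyl gives a 3.3-fold lower number from compound 1 to compound 3 (0.52 log units; beyond the scatter) in this assay. This position therefore accepts a group with a hydrogen-bond donor and more heavy atoms, with a gain rather than a loss. Nothing available explains why this change lowers the number.

The compounds shown leave open whether the amide hydrogen matters, and how an aminomethyl group or a carboxylic acid at this position would compare.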